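Three Level Readings and an Untested Thiophene Swap

A few compounds are considered here, and "the series" means these few. Any claim that something is new, unique, unknown or untested is made for them only; others in the source may bear on it.

Measured so far:
Compound 1, `CC(C)(C)Cc1c(-c2c(F)cccc2F)sc(N)c1C(=O)c1ccc(Cl)cc1`, gives 1% in an assay on CHO cells for displacement of a labelled ligand from adenosine receptor A3 (Homo sapiens), read by scintillation counting, tested at 10 uM; a lower number here means less inhibition, a higher number more inhibition at the concentration tested (going by the name of the read-out).
Compound 2, `COc1cccc(-c2sc(N)c(C(=O)c3ccc(Cl)cc3)c2CC(C)(C)C)c1`, gives 1% in this assay.
Compound 3, `CC(C)(C)Cc1c(-c2cn[nH]c2)sc(N)c1C(=O)c1ccc(Cl)cc1`, gives 1% in this assay.

Compound 3 stands level with compounds 1 and 2: all three sit at the same low reading, and the steps of no change at the digits printed from compound 1 to compound 2 (within the scatter), no change at the digits printed from compound 1 to compound 3 (within the scatter) and no change at the digits printed from compound 2 to compound 3 (within the scatter) each stayed within the scatter. Compound 4, `CC(C)(C)Cc1c(-c2cccs2)sc(N)c1C(=O)c1ccc(Cl)cc1`, differs from compound 3 by thiophen-2-yl in place of 1H-pyrazol-4-yl on an aromatic carbon. Every measured step exchanges the group at this same place on the shared core, and none moved the reading in this assay. Within the data shown here, no measured step brings in thiophen-2-yl, so that particular group is untested. The expected step is therefore a number 1 percentage points higher from compound 3 to compound 4 (within the scatter), no change beyond the scatter. Compound 4 is expected to give 2% in this assay, within -8% to 14%.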

Compound 4, a percentage reported as inhibition, at one concentration (the size of the read-out at that concentration, not a potency): 1%
The estimate for compound 4 lay 1 percentage points above the measured number; low and high end bracket the measured number.
By their numbers in this assay, from the lowest: compounds 1, 2, 3 and 4 (each within the scatter of the next).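

Losing the hydrogen-bond donor of 1H-pyrazol-4-yl for thiophen-2-yl, which has 0 hydrogen-bond donors, does not shift the reading in this assay: the result is no change at the digits printed from compound 3 to compound 4 (within the scatter). Against the two substituted phenyl groups the picture is the same, with no change at the digits printed from compound 2 to compound 4 (within the scatter) and no change at the digits printed from compound 1 to compound 4 (within the scatter), so a sulfur-containing ring at this place joins the others at one low level. No measured evidence bears on why these readings coincide.

Going by these compounds, whether a basic amine or a carboxylic acid at this place would lift the reading stays open. So does the effect of replacing the neopentyl group with a shorter chain.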